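Chloro for dimethylamino on a thioether chalcone scaffold

The compounds below may be only part of what the source reports. "The series", "measured", "known", "first", "only" and "open" are said of these compounds alone.

In a functional assay on DU-145 cells (Homo sapiens) for inhibition, read by trypan blue exclusion, with a stated time of 96 h (a lower number here means a stronger inhibitor of growth, a higher number a weaker inhibitor of growth), compound 2 `CN(C)c1ccc(/C=C(/SCc2ccccc2Cl)C(=O)c2ccc(Cl)cc2)cc1` gives only a limit, > 100000 nM. Compound 1 `O=C(/C(=C\c1ccc(Cl)cc1)SCc1ccccc1Cl)c1ccc(Cl)cc1` in this assay gives 12000 nM. The change chloro in place of dimethylamino on an aromatic carbon thus produced an at least 8.3-fold lower number from compound 2 to compound 1 (0.92 log units; beyond the scatter). Compound 3 `Cc1ccc(CS/C(=C/c2ccc(N(C)C)cc2)C(=O)c2ccc(Cl)cc2)cc1` in this assay likewise gives only a limit, > 100000 nM. The cores of compound 2 and compound 3 differ by 4-methylphenyl in place of 2-chlorophenyl on a saturated chain carbon bound to a sulfur, and the step that the two limits leave unreadable from compound 2 to compound 3 cannot be read because the limit of > 100000 nM in this assay, at which 2 of the 3 values shown sit, covers both ends. Compound 4 `Cc1ccc(CS/C(=C/c2ccc(Cl)cc2)C(=O)c2ccc(Cl)cc2)cc1` has not yet been measured in this assay; it differs from compound 3 by chloro in place of dimethylamino on an aromatic carbon, the same change that was made from compound 2 to compound 1, at a place described in identical words. Compound 4 is expected to show an at least 6.6-fold lower number from compound 3 to compound 4 (0.82 log units; beyond the scatter), an expectation resting on the step of an at least 8.3-fold lower number from compound 2 to compound 1 (0.92 log units; beyond the scatter) in this assay and the fact that compound 3 sits at a limit. The estimate for compound 4 in this assay is 15000 nM, between 4000 nM and 100000 nM.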

Compound 4, concentration for 50% growth inhibition: 10000 nM
Estimate against measurement, compound 4: 1.5-fold (0.18 log units) above, within the range that was stated.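

In this assay, chloro in place of dimethylamino on an aromatic carbon lowered the number on a second core as well, with an at least 10-fold lower number from compound 3 to compound 4 (1.00 log units; beyond the scatter), so the change carried over in direction on the two cores shown, and both steps lie beyond the scatter. Whether it has the same size on both cores is not shown: the same change on two cores in this assay, an at least 8.3-fold lower number (0.92 log units; beyond the scatter) from compound 2 to compound 1 and an at least 10-fold lower number (1.00 log units; beyond the scatter) from compound 3 to compound 4; the limit leaves it open whether they differ. From the compounds shown here alone, with chloro in place, 4-methylphenyl in place of 2-chlorophenyl gives a 1.2-fold lower number from compound 1 to compound 4 (0.08 log units; within the scatter), while the same exchange among the dimethylamino compounds cannot be read, and the full size of the chloro step on either core stays unknown: the limit of > 100000 nM in this assay, at which 2 of the 4 values shown sit.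

The compounds shown leave open how other groups on that aromatic carbon, such as methoxy, fluoro or a nitrile, would compare with chloro and dimethylamino. They also leave open whether the change would carry to a core with another group on the sulfur, such as a longer alkyl chain or a carboxylic acid.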